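Carboxy to Methoxycarbonyl on the Shared Core

This account rests on a few compounds, and the source may have more. Where it says the series, first, only, none or still open, it means among the compounds named here.

Measured compounds:
compound 1, `COc1cc2ncnc(Nc3cccc(C(=O)O)c3)c2cc1OC`: 32%
compound 2, `COCCOc1cc2ncnc(Nc3ccc(B(O)O)cc3)c2cc1OCCOC`: 41%
compound 3, `COCCOc1cc2ncnc(Nc3cccc(B(O)O)c3)c2cc1OCCOC`: "not active" (no number reported)

Three compounds have been run in an assay on isolated protein for inhibition of vascular endothelial growth factor receptor 1 (Homo sapiens), read by ELISA, with a stated time of 20 min, tested at 1 uM; on this read-out higher numbers stand for more inhibition at the one concentration tested (going by the name of the read-out) and lower numbers for less inhibition. Compound 1 gives 32% and compound 2 gives 41%, two numbers that sit within the scatter of each other, so the inhibition in this assay reads level for the pair. Compound 3 returned no number in this assay and is reported as not active. Compound 1 is therefore one of the two compounds with a number, and the other lies within the scatter of it.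

Compound 4, `COC(=O)c1cccc(Nc2ncnc3cc(OC)c(OC)cc23)c1`, has not yet been measured in this assay. It differs from compound 1 in one place: methyl in place of hydrogen on an oxygen next to a carbonyl group. Within the data shown here, no measured pair in this set shares that change, so no step of the same kind is available for comparison. With only a single carbon entering, the step from compound 1 to compound 4 is expected to be small, a number 2 percentage points lower from compound 1 to compound 4 (within the scatter), and not clearly beyond the scatter in either direction. Compound 4 is accordingly expected to give about 30%, with a range from 10% to 50%.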

Compound 4, a percentage reported as inhibition, at one concentration (the size of the read-out at that concentration, not a potency): "not active" (no number reported)
Compound 4: no number reported, and the estimate cannot be compared.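

In this assay, among these compounds, compound 4 has no number, so no step from compound 1 to compound 4 can be read. The compounds shown leave open how far carboxy to methoxycarbonyl shifts the inhibition. Nothing measured here offers an explanation for this result.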